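Aryl groups on the pyrimidine core and NF-kappa-B inhibition

The source may hold more compounds than are shown below. What is called first, only, known or untested is meant among the compounds shown, and "the series" means these compounds.

Measured so far:
compound 1 `CCOC(=O)c1cnc(C)nc1NN1C(=O)C=C(C)C1=O`: 16000 nM
compound 2 `CCOC(=O)c1cnc(-c2cc(Cl)nc(Cl)c2)nc1NN1C(=O)C=C(C)C1=O`: 2000 nM
compound 3 `CCOC(=O)c1cnc(-c2cnc3ccccc3c2)nc1NN1C(=O)C=C(C)C1=O`: 6000 nM

The three compounds share one core and differ only in the group on an aromatic carbon between two ring nitrogen atoms, para to an ethoxycarbonyl group. In a functional assay on Jurkat cells for inhibition of nuclear factor NF-kappa-B complex (Homo sapiens) (on this read-out lower numbers stand for stronger inhibition and higher numbers for weaker inhibition), compound 3 stands second highest of the three numbers: compound 1, with a methyl there, gives 16000 nM, and the step of a 2.7-fold lower number from compound 1 to compound 3 (0.43 log units; beyond the scatter) shows that a quinolin-3-yl lowers the number. Compound 2, carrying a 2,6-dichloropyridin-4-yl, gives 2000 nM; the step of a 3.0-fold higher number from compound 2 to compound 3 (0.48 log units; beyond the scatter) shows the quinolin-3-yl falls short of that.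

Compound 4 `CCOC(=O)c1cnc(-c2ccc(F)cc2)nc1NN1C(=O)C=C(C)C1=O` is not yet measured. It differs from compound 3 in one place: 4-fluorophenyl in place of quinolin-3-yl on an aromatic carbon. Both measured steps that replace the methyl with an aromatic group lower the number, so a 4-fluorophenyl, also aromatic, is expected to keep compound 4 in the range of the two aryl compounds. The expected step is a 1.2-fold lower number from compound 3 to compound 4 (0.08 log units; within the scatter), within the scatter. For compound 4 in this assay the estimate is 5000 nM, with a range from 2000 nM to 12000 nM.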

Compound 4, half-maximal inhibitory concentration: 700 nM
Compound 4: the middle estimate sits 7.1-fold (0.85 log units) above what was measured; measured number outside the range, below it.
By their numbers in this assay, from the lowest: compound 4; then compound 2; then compound 3; then compound 1.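

Being aromatic is not enough to settle the number at this position: quinolin-3-yl and 4-fluorophenyl are both aromatic, yet exchanging one for the other gives an 8.6-fold lower number from compound 3 to compound 4 (0.93 log units; beyond the scatter). The 4-fluorophenyl also goes past the best earlier group, with a 2.9-fold lower number from compound 2 to compound 4 (0.46 log units; beyond the scatter), and the full change from methyl gives a 23-fold lower number from compound 1 to compound 4 (1.36 log units; beyond the scatter), so the lowest number of the four comes from a ring of carbon only that carries a fluorine. Nothing available here explains why these aromatic groups differ so much.

The compounds shown leave open whether the gain belongs to the fluorine or to the carbon-only ring, a question a plain phenyl group would help to answer. As far as these compounds go, how a 4-chlorophenyl or a 4-methoxyphenyl group would compare at this position also remains open.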